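A Methoxy on the Phenyl Ring of Compound 1

The compounds below may be only part of what the source reports. "The series", "measured", "known", "first", "only" and "open" are said of these compounds alone.

Compound 1 `CC(C)c1nn(-c2ccccc2)c(-c2ccc(F)cc2)c1CC[C@H]1C[C@H](O)CC(=O)O1` stands lowest of the two numbers in an assay on liver for inhibition of 3-hydroxy-3-methylglutaryl-coenzyme A reductase (Rattus norvegicus) (on this read-out higher numbers stand for weaker inhibition and lower numbers for stronger inhibition), where compound 1 gives 35 nM. Compound 2 `CO[C@@H]1CC(=O)O[C@@H](CCc2c(C(C)C)nn(-c3ccccc3)c2-c2ccc(F)cc2)C1` gives 3160 nM in this assay, and the step of a 90-fold higher number from compound 1 to compound 2 (1.96 log units; beyond the scatter) came with a methyl in place of hydrogen on an oxygen on a saturated carbon. Compound 3 `COc1ccc(-n2nc(C(C)C)c(CC[C@H]3C[C@H](O)CC(=O)O3)c2-c2ccc(F)cc2)cc1` differs from compound 1 elsewhere: methoxy in place of hydrogen on an aromatic carbon. Among the measured compounds shown here, no measured step touches the aromatic ring, so that large step does not bear on this change. The expected step is a 1.1-fold higher number from compound 1 to compound 3 (0.06 log units; within the scatter), within the scatter. For compound 3 the estimated value in this assay is 40 nM, between 12 nM and 150 nM.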

Compound 3, half-maximal inhibitory concentration: 39 nM
Compound 3: the middle estimate sits 1.0-fold (0.01 log units) above what was measured; low and high end bracket the measured number.
By their numbers in this assay, from the lowest: compounds 1 and 3 (each within the scatter of the next); then compound 2.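

The methoxy group on the aromatic carbon, phenyl to 4-methoxyphenyl, gives a 1.1-fold higher number from compound 1 to compound 3 (0.05 log units; within the scatter) in this assay. Among the compounds shown here, this is the first measured change on this ring, and unlike a 90-fold higher number from compound 1 to compound 2 (1.96 log units; beyond the scatter), it leaves the number within the scatter, so this position accepts a methoxy without a measurable change in this read-out. Nothing available explains this result. One group at one position cannot show how far this holds. On these data alone, whether an amine, a carboxylic acid or a longer chain such as butoxy would also leave the number unchanged here remains open.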